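The source may report more compounds than this note shows. Statements on the series, on what has been measured and on what is new or still open speak of the compounds shown alone.

Measured in an assay on CHO cells for displacement of a labelled ligand from adenosine receptor A1 (Homo sapiens), read by scintillation counting, with a stated time of 60 min, tested at 10 uM; on this read-out lower numbers stand for less inhibition and higher numbers for more inhibition at the one concentration tested (going by the name of the read-out):
compound 1 `CNC(=O)[C@@]12C[C@@H]1[C@@H](n1cnc3cnc(/C=C(\O)c4cnccn4)nc31)[C@H](O)[C@@H]2O` gives 14%;
compound 2 `CNC(=O)[C@@]12C[C@@H]1[C@@H](n1cnc3c(/C=C(\O)c4ccccc4)nc(C#Cc4ccccc4)nc31)[C@H](O)[C@@H]2O` gives 16%;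
compound 3 `CNC(=O)[C@@]12C[C@@H]1[C@@H](n1cnc3c(/C=C(\O)c4ccccc4)nc(Cl)nc31)[C@H](O)[C@@H]2O` gives 30%.

Compound 1 stands lowest of the three numbers in this assay, within the scatter of compound 2 and beyond it only against compound 3. Compound 4 `CNC(=O)[C@@]12C[C@@H]1[C@@H](n1cnc3cnc(C#Cc4ccc(Cl)s4)nc31)[C@H](O)[C@@H]2O` differs from compound 1 by 2-(5-chlorothiophen-2-yl)ethynyl in place of 2-hydroxy-2-(pyrazin-2-yl)ethenyl on an aromatic carbon. Going by the values given here, the one step measured at this position, a number 14 percentage points higher from compound 2 to compound 3 (beyond the scatter), replaces an arylethynyl group by chloro; the change to compound 4 instead introduces an arylethynyl group, and compound 2, which carries such a group, sits within the scatter of compound 1. Among the compounds with values here, no step changes this position while the rest of the molecule of compound 1 is kept. In this assay compound 4 is therefore expected to stay low, with a step of a number 1 percentage points higher from compound 1 to compound 4 (within the scatter), and an estimated 15% (range 0% to 40%).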

Compound 4, a percentage reported as inhibition, at one concentration (the size of the read-out at that concentration, not a potency): < 10%
Compound 4: no number, only a limit; the forecaster's own chance of this, stated with the estimate: 0%; middle value at least 5 percentage points away from the limit.
By their numbers in this assay, from the lowest: compounds 1 and 2 (each within the scatter of the next); then compound 3. At a limit, below all of these: compound 4.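

Replacing 2-hydroxy-2-(pyrazin-2-yl)ethenyl with 2-(5-chlorothiophen-2-yl)ethynyl gives the first step read at this position, between two ring nitrogen atoms, on the core of compound 1; in this assay it is a number at least 4 percentage points lower from compound 1 to compound 4 (that floor lies within the scatter). The entry for compound 4 is a limit of the assay, not a number: the limit of < 10% in this assay, at which 1 of the 4 values shown sits.

This change therefore brings no rise in inhibition, while the true size of the step stays unresolved. The compounds shown leave open how an amine or a carboxylic acid at this position would read on the same core. They also leave open what the chlorine on the thiophene contributes.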